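Changing the Aryl Group on the Amide Carbonyl

The source may report more compounds than this note shows. Statements on the series, on what has been measured and on what is new or still open speak of the compounds shown alone.

Compound 2 `O=C(Nc1cccc(-c2oc3cc(-c4ccc(F)cc4)ccc3c(=O)c2O)c1)c1ccc(Cl)nc1` gives 2890 nM in a functional assay on MCF7 cells (Homo sapiens) for antiproliferative activity, read by CCK-8 assay, with a stated time of 72 h; on this read-out lower numbers stand for stronger inhibition and higher numbers for weaker inhibition. Compound 1 `COc1ccccc1C(=O)Nc1cccc(-c2oc3cc(-c4ccc(F)cc4)ccc3c(=O)c2O)c1` gives 2100 nM, and the step of a 1.4-fold higher number from compound 1 to compound 2 (0.14 log units; within the scatter) lies within the scatter, so the two numbers cannot be told apart. Compound 3 `O=C(Nc1cccc(-c2oc3cc(-c4ccc(F)cc4)ccc3c(=O)c2O)c1)c1ccc(-c2ccccc2)cc1` alters compound 2 at the same place: 4-phenylphenyl in place of 6-chloropyridin-3-yl on a carbonyl carbon. Among the compounds with values here, the only step that bears on this change, a 1.4-fold higher number from compound 1 to compound 2 (0.14 log units; within the scatter), also replaced the group on the carbonyl carbon and stayed within the scatter. On that basis the expected step is a 1.0-fold higher number from compound 2 to compound 3 (0.02 log units; within the scatter), nothing beyond the scatter. Compound 3 is therefore estimated at 3000 nM, with a range from 1200 nM to 7500 nM.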

Compound 3, half-maximal inhibitory concentration: 38500 nM
Compound 3: the middle estimate sits 13-fold (1.11 log units) below what was measured; measured number outside the range, above it.
By their numbers in this assay, from the lowest: compounds 1 and 2 (each within the scatter of the next); then compound 3.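

Replacing 6-chloropyridin-3-yl with 4-phenylphenyl (a 13-fold higher number from compound 2 to compound 3 (1.12 log units; beyond the scatter)) and replacing 2-methoxyphenyl with 4-phenylphenyl (an 18-fold higher number from compound 1 to compound 3 (1.26 log units; beyond the scatter)) both weaken inhibition by a large margin in this assay. The group on this carbonyl carbon can therefore change the result strongly, which the step between the two single-ring groups did not show. No available measurement explains the loss.

On these data alone, how a plain phenyl or a 4-aminophenyl group would behave at this position stays open. The compounds shown cannot tell whether the second ring of 4-phenylphenyl alone accounts for the drop.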